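Isopropyl for (pyridin-4-yl)methyl on the sulfur

The compounds below may be only part of what the source reports. "The series", "measured", "known", "first", "only" and "open" are said of these compounds alone.

Compound 3 (`Cc1c(Cc2c(F)cccc2F)nc(SCc2ccncc2)[nH]c1=O`) has no numeric reading yet. In an ADME assay on MT4 cells (Homo sapiens) for cytotoxicity, read by MTT assay (a higher number here means that more compound is tolerated, a lower number that less compound is tolerated), compound 3 gives > 70000 nM which is a limit and not a number. Compound 1 (`Cc1c(Cc2c(F)cccc2F)nc(SCc2ccccc2)[nH]c1=O`) reads > 70000 nM and this is also a limit. Compound 2 (`Cc1c(Cc2c(F)cccc2F)nc(SCc2cccnc2)[nH]c1=O`) reads > 70000 nM and this too is a limit. Summary of the measured set: the limit of > 70000 nM in this assay, at which 3 of the 3 values shown sit, and no numeric reading so far.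

The next change leads to compound 4 (`Cc1c(Cc2c(F)cccc2F)nc(SC(C)C)[nH]c1=O`) and puts isopropyl in place of (pyridin-4-yl)methyl on a sulfur with the rest of the structure unchanged.

Among the measured compounds shown here, three measured steps concern the same substituent on the sulfur: a step that the two limits leave unreadable from compound 1 to compound 2 then a step that the two limits leave unreadable from compound 1 to compound 3 then a step that the two limits leave unreadable from compound 2 to compound 3 and none of them provides a size to carry over. Each of them also keeps a ring in the substituent, so none matches the loss of the ring in this change.

Resting on compound 3 and its limit of > 70000 nM no step beyond the scatter is expected in this assay in either direction. The expected step is a number no higher from compound 3 to compound 4 (the limit leaves the size open) as estimated here. Compound 4 is estimated at 70000 nM with an expected range from 25000 nM to 140000 nM and a report as a limit is the likelier outcome.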

Compound 4, half-maximal cytotoxic concentration: > 77000 nM
Compound 4: only a limit was reported; the forecaster's own chance of this, stated with the estimate: 65%; middle value at least 1.1-fold (0.04 log units) away from the limit.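

In this assay compound 4 gives > 77000 nM, which is a limit. Compound 1, compound 2 and compound 3 are also reported only as limits, so none of their steps to compound 4 can be read. The compounds shown leave open whether any substituent on the sulfur changes the tolerated concentration in this assay.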